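The compounds below may be only part of what the source reports. "The series", "measured", "known", "first", "only" and "open" are said of these compounds alone.

In a physicochemical assay for solubility, read by turbidimetry, measured as kinetic solubility, at pH 7.4 (a higher number here means a more soluble compound, a lower number a less soluble compound), compound 1 (`CC1SC(c2cccc(C(=O)NCCCCc3ccccc3)c2)N(c2ccc(C3CC3)cc2)C1=O`) gives 2000 nM, while compound 2 (`COc1ccccc1N1C(=O)CSC1c1cc(F)cc(C(=O)NCCCCc2ccccc2)c1`) gives 10000 nM, the higher of the two numbers and a gap beyond the usual scatter. These compounds differ in more than one place, so their gap cannot be tied to any single change. Compound 3 (`C#Cc1cc(C(=O)NCCCCc2ccccc2)cc(C2SCC(=O)N2c2ccccc2OC)c1`) carries ethynyl in place of fluoro on an aromatic carbon. Going by the values given here, no measured pair shows this change, so only a modest fall in this assay, perhaps not beyond the scatter, is expected. The estimated change is a 1.7-fold lower number from compound 2 to compound 3 (0.22 log units; within the scatter). For compound 3 the expected value is 6000 nM, within a range of 2000 nM to 12000 nM.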

Compound 3, solubility: 10000 nM
Compound 3: the middle estimate sits 1.7-fold (0.22 log units) below what was measured, and the stated range covers the measured number.
By their numbers in this assay, from the lowest: compound 1; then compounds 2 and 3 (each within the scatter of the next).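

In this assay, going by these compounds alone, placing ethynyl in place of fluoro on this aromatic carbon gives no change at the digits printed from compound 2 to compound 3 (within the scatter), the first comparison here that differs in only one place. At this position, then, two carbon atoms in place of one fluorine leave the reading unmoved. No measurement here offers an explanation for this result. On these data alone, whether an amine or a carboxylic acid at this position would move the reading remains open. Compound 1 differs from compound 2 in more than one place, so the step between them still cannot be read.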